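Swapping sec-butyl for tert-butyl on the ring nitrogen

The compounds below may be only part of what the source reports. "The series", "measured", "known", "first", "only" and "open" are said of these compounds alone.

compound 1 `CCCCN1C(=O)NC2(CSC3=C2C(=O)c2ccccc2C3=O)C1=O` gives 740 nM
compound 2 `CCC(C)N1C(=O)NC2(CSC3=C2C(=O)c2ccccc2C3=O)C1=O` gives 562 nM

Going by the values given here, in a functional assay on SW-620 cells (Homo sapiens) for inhibition (a higher number here means a weaker inhibitor, a lower number a stronger inhibitor), compound 2 gives 562 nM and lies within the scatter of compound 1, the only other measured compound, so the two cannot be ranked. The next change, from compound 2 to compound 3 `CC(C)(C)N1C(=O)NC2(CSC3=C2C(=O)c2ccccc2C3=O)C1=O`, is tert-butyl in place of sec-butyl on an amide-type nitrogen in a ring and puts tert-butyl in place of sec-butyl on an amide-type nitrogen in a ring. Among the compounds with values here, only one measured step bears on this, a 1.3-fold lower number from compound 1 to compound 2 (0.12 log units; within the scatter) at the same place, and it stays within the scatter. Within the data shown here, no measurement of tert-butyl exists yet, so with only that small step to go on, no shift beyond the scatter is expected in either direction. The expected step is a 1.1-fold higher number from compound 2 to compound 3 (0.03 log units; within the scatter) and would remain within the scatter. Compound 3 is estimated at 600 nM with an expected range from 230 nM to 1500 nM in this assay for now.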

Compound 3, half-maximal inhibitory concentration: 900 nM
For compound 3 the middle estimate is 1.5-fold (0.18 log units) below the measured one, within the range that was stated.
By their numbers in this assay, from the lowest: compounds 2, 1 and 3 (each within the scatter of the next).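

In this assay the tert-butyl compound shows a 1.6-fold higher number from compound 2 to compound 3 (0.20 log units; within the scatter) and a 1.2-fold higher number from compound 1 to compound 3 (0.09 log units; within the scatter) and both steps stay within the scatter. Butyl, sec-butyl and tert-butyl on this amide-type nitrogen in a ring therefore cannot be told apart in this assay, so the change from sec-butyl to tert-butyl has no readable effect here, and the three compounds set no order among these groups. Nothing at hand accounts for this result.

From the compounds shown here alone, it remains open whether a group of another kind at this nitrogen, such as a longer chain, a benzyl group or a chain ending in an amine, would move the number beyond the scatter. Going by these compounds, it is equally open what a plain hydrogen on this nitrogen would give on the shared core.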